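A few compounds are considered here, and "the series" means these few. Any claim that something is new, unique, unknown or untested is made for them only; others in the source may bear on it.

Of the compounds shown here, two carrying the same shared core have been tested so far. Compound 1 `CCC/C=C/C(=O)Nc1cccc(Oc2nc(Nc3cccc(OC)c3)nc3ccsc23)c1` gives 8090 nM in a functional assay on A-431 cells (Homo sapiens) for inhibition, read by MTT assay, with a stated time of 72 h; on this read-out higher numbers stand for weaker inhibition and lower numbers for stronger inhibition. Compound 2 `CC/C=C/C(=O)Nc1cccc(Oc2nc(Nc3cccc(C#N)c3)nc3ccsc23)c1` gives 36200 nM in this assay, the higher of the two numbers, and the gap to compound 1 lies beyond the usual scatter of such measurements. Compound 3 `CCC/C=C/C(=O)Nc1cccc(Oc2nc(Nc3cccc(C#N)c3)nc3ccsc23)c1` has not yet been measured. It differs from compound 2 in one place: methyl in place of hydrogen on a saturated chain carbon, two bonds along the chain from a double-bonded chain carbon. No comparable single change has been measured here, so the size of this step is open. Compound 1, which carries the longer chain, shows a lower number than compound 2, but it also carries a different group on its outer ring, so the two structural differences cannot be separated. A small downward movement within or near the scatter is expected, giving a 1.4-fold lower number from compound 2 to compound 3 (0.16 log units; within the scatter). Compound 3 is therefore estimated at 25000 nM, within a range from 9000 nM to 60000 nM.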

Compound 3, half-maximal inhibitory concentration: 20400 nM
Compound 3: the middle estimate sits 1.2-fold (0.09 log units) above what was measured, within the range that was stated.
By their numbers in this assay, from the lowest: compound 1; then compounds 3 and 2 (each within the scatter of the next).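

In this assay the methyl added on this saturated chain carbon, which turns but-1-en-1-yl into pent-1-en-1-yl, gives a 1.8-fold lower number from compound 2 to compound 3 (0.25 log units; within the scatter) and so cannot be told apart from the usual scatter of repeated measurements. With the chain now the same, cyano in place of methoxy on an aromatic carbon can be read on its own as a 2.5-fold higher number from compound 1 to compound 3 (0.40 log units; beyond the scatter) and this modest step lies beyond the scatter, which separates two differences that stayed mixed before. Nothing measured here explains why either step has this size.

From the compounds shown here alone, whether a longer chain, or an amine at the end of the chain, would shift the number beyond the scatter remains open. Also open, going by these compounds, is how a halogen such as chlorine would compare with cyano and methoxy at that aromatic carbon.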